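Chloro for fluoro on the pendant aryl ring: expected clearance

The source may hold more compounds than are shown below. What is called first, only, known or untested is meant among the compounds shown, and "the series" means these compounds.

Of the compounds shown here, three sharing one core have been measured in an ADME assay on microsomes from liver (Homo sapiens) for metabolic stability, tested at 2.5 uM; on this read-out lower numbers stand for slow clearance and higher numbers for fast clearance. Compound 1 `COc1cccc(-c2c(S(=O)(=O)c3cc(Cl)cc(Cl)c3)cnc3c(F)cccc23)c1` gives 2.31 mL/min, compound 2 `COc1ccc(S(=O)(=O)c2cnc3c(F)cccc3c2-c2ccc(Cl)cc2)cc1` gives 1.05 mL/min, and compound 3 `O=S(=O)(c1cc(Cl)cc(Cl)c1)c1cnc2c(F)cccc2c1-c1ccc(F)cc1` gives 1.01 mL/min. Compound 3 has the lowest of the three numbers, though its value and that of compound 2 lie within the scatter of each other; only compound 1 sits clearly apart, as the step of a 2.3-fold lower number from compound 1 to compound 3 (0.36 log units; beyond the scatter) shows. Compound 4 `O=S(=O)(c1cc(Cl)cc(Cl)c1)c1cnc2c(F)cccc2c1-c1ccc(Cl)cc1` is not yet measured. It differs from compound 3 in one place: chloro in place of fluoro on an aromatic carbon on an aromatic carbon of the six-membered carbon-only ring. Going by the values given here, no measured step makes this same change. Among the compounds with values here, the only measured step, from compound 1 to compound 3, swaps a 3-methoxyphenyl for a 4-fluorophenyl and moves the number modestly; compound 2, which carries the 4-chlorophenyl of compound 4 on a different partner, sits within the scatter of compound 3. A step of a 1.2-fold higher number from compound 3 to compound 4 (0.07 log units; within the scatter) is therefore expected, with no change beyond the scatter, so compound 4 is estimated at 1.2 mL/min, within 0.6 mL/min to 2.4 mL/min.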

Compound 4, intrinsic clearance in a liver preparation (reported as CLH), per the amount of preparation that the assay uses: 0.78 mL/min
Compound 4: middle estimate off by 1.5-fold (0.19 log units), on the high side; the range from low to high includes it.
By their numbers in this assay, from the lowest: compounds 4, 3 and 2 (each within the scatter of the next); then compound 1.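

In this assay, going by these compounds alone, 4-chlorophenyl in place of 4-fluorophenyl gives the first direct reading of this change, and a 1.3-fold lower number from compound 3 to compound 4 (0.11 log units; within the scatter) shows that the two halogens cannot be told apart at this place, para to a large group. With the 4-chlorophenyl held fixed, 3,5-dichlorophenyl in place of 4-methoxyphenyl on the sulfonyl sulfur also stays within the scatter, at a 1.3-fold lower number from compound 2 to compound 4 (0.13 log units; within the scatter). By contrast, 4-chlorophenyl in place of 3-methoxyphenyl gives a 3.0-fold lower number from compound 1 to compound 4 (0.47 log units; beyond the scatter), which is beyond the scatter and in the same direction as a 2.3-fold lower number from compound 1 to compound 3 (0.36 log units; beyond the scatter), so compound 1 stands apart from both halogen analogues.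

Nothing available explains these numbers. From the compounds shown here alone, whether a bromo, an amine or a carboxylic acid at this same place would keep the number in this range remains open.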